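The source may report more compounds than this note shows. Statements on the series, on what has been measured and on what is new or still open speak of the compounds shown alone.

Measured compounds:
- compound 1 `O=c1[nH]cc(S(=O)(=O)Nc2ccccc2-c2cn(-c3ccccc3F)nn2)c(=O)[nH]1`: in a functional assay on HepG2 cells (Homo sapiens) for antiproliferative activity, read by MTT assay, with a stated time of 24 h (on this read-out lower numbers stand for stronger inhibition and higher numbers for weaker inhibition), compound 1 gives 12500 nM
- compound 2 `O=c1[nH]cc(S(=O)(=O)Nc2ccccc2-c2cn(-c3cccc(F)c3)nn2)c(=O)[nH]1`: compound 2 gives only the limit > 20000 nM
- compound 3 `Cc1ccc(-n2cc(-c3cccc(NS(=O)(=O)c4c[nH]c(=O)[nH]c4=O)c3)nn2)cc1`: compound 3 gives only the limit > 20000 nM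

Compound 3 stands at the limit of > 20000 nM in this assay, at which 2 of the 3 values shown sit, so no number is known for it. Compound 4 `O=c1[nH]cc(S(=O)(=O)Nc2cccc(-c3cn(-c4cccc(Cl)c4)nn3)c2)c(=O)[nH]1` differs from it by 3-chlorophenyl in place of 4-methylphenyl on an aromatic nitrogen. Going by the values given here, the only measured step, an at least 1.6-fold higher number from compound 1 to compound 2 (0.20 log units; that floor lies within the scatter), concerns a fluorine moved between two places on a phenyl and ends at a limit; it does not cover a chlorine replacing a methyl. With compound 3 already at its limit, compound 4 is expected to stay near it, so the step of a number no higher from compound 3 to compound 4 (the limit leaves the size open) is estimated to be within the scatter. Compound 4 is therefore expected to give about 20000 nM, between 7000 nM and 60000 nM.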

Compound 4, half-maximal inhibitory concentration: 4200 nM
Beside the measured number, compound 4's estimate is 4.8-fold (0.68 log units) above it, and the stated range ends above it.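

Going by these compounds alone, the group on the aromatic nitrogen can shift the result beyond the scatter, with an at least 4.7-fold lower number from compound 3 to compound 4 (0.67 log units; beyond the scatter) in this assay, whereas the only earlier step at this position had a floor within the scatter. The true size of this new step stays unknown because compound 3 gives only a limit: the limit of > 20000 nM in this assay, at which 2 of the 4 values shown sit.

The change replaces the methyl with a chlorine and also alters where the substituent sits on the phenyl, and the compounds shown do not separate these two parts. As far as these compounds go, how 3-methylphenyl or 4-chlorophenyl would read here remains open.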